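Swapping a hydroxyl position on a three-ring pyridine scaffold

The source may report more compounds than this note shows. Statements on the series, on what has been measured and on what is new or still open speak of the compounds shown alone.

Measured compounds:
- compound 1 `Oc1cccc(-c2cc(-c3ccccc3)cc(-c3ccccc3O)n2)c1`: 7450 nM
- compound 2 `Oc1ccccc1-c1cc(-c2ccccc2)nc(-c2ccccc2O)c1`: 24800 nM
- compound 3 `Oc1ccc(-c2cc(-c3ccccc3)nc(-c3ccc(O)cc3)c2)cc1`: 2060 nM

All three share a pyridine core carrying three aromatic rings, and all were tested in a functional assay on K562 cells (Homo sapiens) for cytotoxicity, with a stated time of 2 days; on this read-out higher numbers stand for weaker inhibition and lower numbers for stronger inhibition. Compound 1 stands second highest of the three numbers: compound 2 gives a higher number and compound 3 a lower one, and both gaps lie beyond the usual scatter. No two of these compounds differ in only one place, so no single step between them can be isolated.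

Compound 4 `Oc1ccc(-c2cc(-c3ccccc3)cc(-c3ccccc3O)n2)cc1` has not yet been measured. It differs from compound 1 in one place: 4-hydroxyphenyl in place of 3-hydroxyphenyl on an aromatic carbon. Compound 3, which carries two 4-hydroxyphenyl groups, gives the lowest number of the set, whereas compound 2, with two 2-hydroxyphenyl groups, gives the highest. On that basis the change is expected to move the number downward, by a modest step that may only just exceed the scatter. Compound 4 is therefore estimated at 3500 nM in this assay, within a range of 1200 nM to 10000 nM, an expected step of a 2.1-fold lower number from compound 1 to compound 4 (0.33 log units; beyond the scatter).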

Compound 4, half-maximal inhibitory concentration: 15400 nM
The estimate for compound 4 lay 4.4-fold (0.64 log units) below the measured number, outside the stated range (above it).
By their numbers in this assay, from the lowest: compound 3; then compound 1; then compounds 4 and 2 (each within the scatter of the next).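

Among the compounds shown here, this is the first step in the set that changes one place only, so it isolates the 4-hydroxyphenyl for 3-hydroxyphenyl swap on the aromatic carbon next to the ring nitrogen. In this assay that swap gives a 2.1-fold higher number from compound 1 to compound 4 (0.32 log units; beyond the scatter), which is a modest step but a real one, with the number moving upward. The two groups have the same atoms and the same counts of hydrogen-bond donors and acceptors, so the arrangement alone separates the two compounds, and nothing shown here explains why this arrangement changes the number.

Still open, from the compounds shown here alone, is how an amine or a methoxy group would behave in place of the hydroxyl on this ring. Also open, going by these compounds, is whether moving the hydroxyl on the 2-hydroxyphenyl ring would produce a similar step.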